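Thienyl side group swap in an EP4 antagonist series

This account rests on a few compounds, and the source may have more. Where it says the series, first, only, none or still open, it means among the compounds named here.

Of the compounds shown here, two have numbers so far. Compound 1 `C[C@H](NC(=O)c1c(Cc2cc(F)c(Cl)cc2Cl)sc2c1CCOC2)c1ccc(C(=O)O)cc1` gives, in a functional assay on CHO/Galpha16 cells for antagonist activity at prostaglandin E2 receptor EP4 subtype (Homo sapiens), read by calcium flux, with a stated time of 15 min (a lower number here means a stronger inhibitor, a higher number a weaker inhibitor), a value of 2.5 nM. Compound 2 `C[C@H](NC(=O)c1c(CCc2ccc(F)cc2)sc2c1CCN(C(=O)OC(C)(C)C)C2)c1ccc(C(=O)O)cc1` differs from compound 1 in more than one place. In this assay compound 2 gives a value of 315 nM. Compound 1 thus stands at the lowest of the two numbers, with compound 2 well beyond the scatter from it.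

Compound 3 `C[C@H](NC(=O)c1c(C#Cc2ccc(F)cc2)sc2c1CCOC2)c1ccc(C(=O)O)cc1` has not been measured. It differs from compound 1 as follows: a group of 9 heavy atoms (8 carbon, 1 fluorine; one six-membered aromatic ring of carbon only) in place of a group of 10 heavy atoms (7 carbon, 1 fluorine, 2 chlorine; one six-membered aromatic ring of carbon only), on an aromatic carbon. The two chlorines of compound 1 leave with the group, and the group that enters carries a triple bond outside aromatic rings in their stead.

Among the compounds with values here, no step between measured compounds that differ in one place is known, so there is nothing to calibrate this change against. Given that compound 1 holds the lower number and the only other point, compound 2, sits far higher, the step is expected to go upward, toward a weaker inhibitor, by a moderate amount beyond the scatter, an 8.0-fold higher number from compound 1 to compound 3 (0.90 log units; beyond the scatter). Compound 3 is accordingly estimated in this assay at 20 nM, with a range from 4 nM to 120 nM.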

Compound 3, half-maximal inhibitory concentration: 15.8 nM
The estimate for compound 3 lay 1.3-fold (0.10 log units) above the measured number, and the stated range covers the measured number.
By their numbers in this assay, from the lowest: compound 1; then compound 3; then compound 2.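

In this assay, within the data shown here, placing 2-(4-fluorophenyl)ethynyl on the aromatic carbon next to the ring sulfur, where compound 1 carries its group with two chlorines, gives a 6.3-fold higher number from compound 1 to compound 3 (0.80 log units; beyond the scatter) and is the first single-place comparison available at this position. The position therefore accepts a group with a triple bond outside aromatic rings and no chlorine, and compound 3 at 15.8 nM stays in the low nanomolar range, though the change costs a step beyond the scatter. No measurement bears on what lies behind this step, and the pair changes the chlorine content and the triple bond together, so their separate contributions cannot be assigned from these data.

Open, on these data alone, is whether chlorine on the aromatic ring of the 2-(4-fluorophenyl)ethynyl group would bring the number back toward that of compound 1, or whether the triple bond alone sets the step. Also open, as far as these compounds go, is how this position responds to a pyridine ring in place of the carbon-only aromatic ring, or to a nitrile on that ring in place of fluorine.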